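The compounds below may be only part of what the source reports. "The series", "measured", "known", "first", "only" and "open" are said of these compounds alone.

Measured so far in a functional assay on HL-60 cells (Homo sapiens) for cytotoxicity, read by MTT assay, with a stated time of 24 h; a lower number here means a stronger inhibitor, a higher number a weaker inhibitor:
- compound 1 `CCCCn1cc(Cn2nc(N)c3c(C(F)(F)F)cc(-c4ccccc4)nc32)nn1`: 36.7 ug/mL
- compound 2 `Nc1nn(Cc2cn(-c3ccc(F)c(Cl)c3)nn2)c2nc(-c3ccccc3)cc(C(F)(F)F)c12`: 35 ug/mL
- compound 3 `Nc1nn(Cc2cn(CC(=O)Nc3ccccc3)nn2)c2nc(-c3ccccc3)cc(C(F)(F)F)c12`: 96.3 ug/mL

Compound 1 stands at the lower end of these three numbers, and a 1.0-fold lower number from compound 1 to compound 2 (0.02 log units; within the scatter) does not separate it from its nearest neighbour. Compound 3 lies apart, with a 2.6-fold higher number from compound 1 to compound 3 (0.42 log units; beyond the scatter).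

The step followed here leads to compound 4 `Nc1nn(Cc2cn(CC(=O)Nc3ccc(F)cc3)nn2)c2nc(-c3ccccc3)cc(C(F)(F)F)c12`, which has not yet been measured. The difference is (4-fluorophenyl)carbamoyl in place of propyl on a saturated chain carbon bound to an aromatic nitrogen.

Within the data shown here, the closest precedent is a 2.6-fold higher number from compound 1 to compound 3 (0.42 log units; beyond the scatter), where phenylcarbamoyl enters at the same place and the only contrast with compound 4 is the fluorine on the ring. A second modest step, a 2.8-fold higher number from compound 2 to compound 3 (0.44 log units; beyond the scatter), arrives at the same compound from the aryl side. Among the measured compounds shown here, in a 1.0-fold lower number from compound 1 to compound 2 (0.02 log units; within the scatter), a halogen-bearing aryl group replaces butyl, but that comparison does not isolate the fluorine, and no measured pair does.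

A modest move towards a higher number, and so a weaker inhibitor in this assay, is therefore expected, of about the size seen for compound 3. The expected step is a 2.3-fold higher number from compound 1 to compound 4 (0.36 log units; beyond the scatter). The estimate for compound 4 is 85 ug/mL, with an expected range of 45 ug/mL to 160 ug/mL.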

Compound 4, half-maximal inhibitory concentration: 44.8 ug/mL
The estimate for compound 4 lay 1.9-fold (0.28 log units) above the measured number; measured number below the stated range.
By their numbers in this assay, from the lowest: compounds 2, 1 and 4 (each within the scatter of the next); then compound 3.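

In this assay, the (4-fluorophenyl)carbamoyl group is tolerated on the saturated chain carbon bound to an aromatic nitrogen, with no separation from the butyl compound (a 1.2-fold higher number from compound 1 to compound 4 (0.09 log units; within the scatter)) or from the aryl compound (a 1.3-fold higher number from compound 2 to compound 4 (0.11 log units; within the scatter)). The higher number of compound 3 therefore does not hold for both carbamoyl compounds shown, and compound 4 goes against any reading that a carbamoyl group at this place raises the number. The new information is that this outcome turns on a small change on the aromatic ring: fluoro in place of hydrogen on an aromatic carbon gives a step beyond the scatter (a 2.1-fold lower number from compound 3 to compound 4 (0.33 log units; beyond the scatter)), which puts compound 4 back among compounds 1 and 2, and no measurement explaining this shift is available.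

As far as these compounds go, only hydrogen and fluoro are compared on this ring, so it remains open whether chloro, methoxy or a carboxylic acid there would follow compound 4 or compound 3. From the compounds shown here alone, it also remains open whether a longer chain in place of butyl, or an amine on that chain, would move the number beyond the level shared by compounds 1, 2 and 4.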